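Swapping the aryl ether of compound 1 for a thioether

The source may report more compounds than this note shows. Statements on the series, on what has been measured and on what is new or still open speak of the compounds shown alone.

Compound 1, whose structure is `Nc1cc(N)c2nc(-c3ccccc3)c(Oc3ccc(Cl)c(Cl)c3)nc2c1`, was tested in a functional assay on UACC-62 cells (Homo sapiens) for inhibition, read by sulforhodamine B assay, with a stated time of 48 h (on this read-out lower numbers stand for stronger inhibition of growth and higher numbers for weaker inhibition of growth), and gave 47900 nM. Going by the values given here, of the three compounds measured so far, compound 1 holds the highest number. Compound 3, drawn as `COc1ccc(CNc2nc3cc(N)cc(N)c3nc2-c2ccccc2)cc1`, gives 29500 nM in this assay, which sits within the usual scatter of the number for compound 1, so the two cannot be told apart. Compound 2, with structure `COc1cc(CNc2nc3cc(N)cc(N)c3nc2-c2ccccc2)cc(OC)c1OC`, gives 15500 nM in this assay, a number that lies beyond the scatter below that of compound 1.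

The unmeasured compound 4, with structure `COc1ccc(Sc2nc3cc(N)cc(N)c3nc2-c2ccccc2)cc1`, differs from compound 1 by the change ((4-methoxyphenyl)sulfanyl in place of 3,4-dichlorophenoxy on an aromatic carbon). Among the compounds with values here, no pair of measured compounds repeats this change, so its size is not known from the data. Since compound 3, which also carries a 4-methoxy-substituted aromatic ring in place of the 3,4-dichlorophenoxy group, gives 29500 nM, compound 4 is expected to show a modest step toward a lower number, of the size a 1.9-fold lower number from compound 1 to compound 4 (0.28 log units; within the scatter), though one that may fall within the scatter. The estimate for compound 4 in this assay is therefore 25000 nM, with a range from 8000 nM to 70000 nM.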

Compound 4, concentration for total growth inhibition: < 100000 nM
Compound 4 gave a limit, no number; the forecaster's own chance of this, stated with the estimate: 10%; the middle value is on the limit's open side.
By their numbers in this assay, from the lowest: compounds 2, 3 and 1 (each within the scatter of the next, the first and the last beyond it).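

In this assay compound 4 gives < 100000 nM, which is a limit and not a number. Going by these compounds alone, no step between compound 1 and compound 4 can therefore be read. The compounds shown leave open whether (4-methoxyphenyl)sulfanyl in place of 3,4-dichlorophenoxy changes the result in this assay at all.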